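The source may report more compounds than this note shows. Statements on the series, on what has been measured and on what is new or still open speak of the compounds shown alone.

In an ADME assay on Vero cells (Chlorocebus sabaeus) for cytotoxicity, read by MTT assay, with a stated time of 72 h (on this read-out lower numbers stand for higher toxicity in this test and higher numbers for lower toxicity in this test), compound 2 `COC(=O)c1cc(-c2cccc(NC(=O)c3ccc(OCc4ccc(Cl)cc4)cc3)c2)on1` gives only a limit, > 80 ug/mL. Compound 1 `COC(=O)c1cc(-c2cccc(NC(=O)c3ccc(/C=C/C(=O)c4cccc(F)c4)cc3)c2)on1` also reaches only a limit in this assay, > 40 ug/mL. Going by the values given here, the one measured step, a step that the two limits leave unreadable from compound 1 to compound 2, therefore has no readable size: its two ends sit at different limits, one at the limit of > 40 ug/mL in this assay, at which 1 of the 2 values shown sits, and the other at the limit of > 80 ug/mL in this assay, at which 1 of the 2 values shown sits. Compound 3 `COC(=O)c1cc(-c2cccc(NC(=O)c3ccc(/C=C/C(=O)c4ccccc4)cc3)c2)on1` has not yet been tested in this assay. It differs from compound 2 by 2-benzoylethenyl in place of (4-chlorobenzyl)oxy on an aromatic carbon. Among the compounds with values here, no measured step bears directly on this change; the only step available runs the other way, from the enone of compound 1 to the benzyl ether of compound 2, and it stays unreadable. Compound 1 carries the same 2-benzoylethenyl group as compound 3 with a fluorine added, and its result is a limit. Compound 3 is thus expected to show no cytotoxicity within the tested range, and the step of an at least 1.3-fold lower number from compound 2 to compound 3 (0.12 log units; that floor lies within the scatter) is expected to be unreadable or within the scatter. The estimate for compound 3 is 60 ug/mL, ranging from 30 ug/mL to 150 ug/mL.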

Compound 3, half-maximal cytotoxic concentration: > 50 ug/mL
Compound 3 was reported as a limit; the forecaster's own chance of this, stated with the estimate: 70%; the middle value is on the limit's open side.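

In this assay compound 3 also gives only a limit: the limit of > 50 ug/mL in this assay, at which 1 of the 3 values shown sits. Its steps from compound 1 and from compound 2 join limits, and neither can be read. The compounds shown leave open where the half-maximal cytotoxic concentration of each compound lies, and whether either change alters it at all.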